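The compounds below may be only part of what the source reports. "The series", "measured", "known", "first", "only" and "open" are said of these compounds alone.

Measured compounds in an assay on HEK293 cells for antagonist activity at Neuronal acetylcholine receptor; alpha3/beta4 (Rattus norvegicus), read by FLIPR, using a membrane potential dye; on this read-out lower numbers stand for stronger inhibition and higher numbers for weaker inhibition:

Compound 1 `CO[C@H]1CC[C@H]2CCN(C)[C@H]2C1` gives > 300000 nM, which is a limit of this assay and not a number.

Compound 2 `CN1CC[C@@H]2CC[C@H](OCc3ccccc3)C[C@@H]21` gives > 300000 nM, also a limit.

Compound 3 `CO[C@H]1CC=C2CCN(C)[C@H]2C1` gives > 300000 nM, again a limit.

Compound 3 therefore stands nowhere within the measured range of this assay: only a limit is known for it, and the two other values shown are limits of the same kind, as stated in the limit of > 300000 nM in this assay, at which 3 of the 3 values shown sit. Compound 4 `CN1CCC2=CC[C@H](OCc3ccccc3)C[C@@H]21` differs from compound 3 by phenyl in place of hydrogen on a saturated chain carbon bound to an oxygen on a saturated carbon. For the measured compounds named here, the one measured step of the same kind is a step that the two limits leave unreadable from compound 1 to compound 2, and its size cannot be read, since both ends of it sit at the limit. No readable step is available, and there is nothing to suggest that this change moves the value into the measurable range of this assay. The expectation for compound 4 is that this assay again returns only a limit, with a number no higher from compound 3 to compound 4 (the limit leaves the size open) as the estimated step. Compound 4 is thus estimated at 300000 nM, within 100000 nM to 1000000 nM.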

Compound 4, half-maximal inhibitory concentration: > 300000 nM
Compound 4: a limit, no number (the forecaster's own chance of this, stated with the estimate: 90%); the middle value sits exactly at the limit.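

The step between compound 3 and compound 4 cannot be read in this assay, as both values are limits and not numbers. The compounds shown leave open whether phenyl in place of hydrogen changes inhibition at all, and how far any compound lies from the measurable range: the limit of > 300000 nM in this assay, at which 4 of the 4 values shown sit.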